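The compounds below may be only part of what the source reports. "The series", "measured", "known", "first", "only" and "open" are said of these compounds alone.

Measured so far in a functional assay on MDA-MB-231 cells (Homo sapiens) for cytotoxicity, read by sulforhodamine B assay, with a stated time of 48 h, tested at 1 uM; a higher number here means a weaker effect of the compound at the concentration tested, a lower number a stronger effect:

compound 1 `COc1cc(C)cc(-c2c(-c3ccnc(-c4ccc(N(C)C)cc4)c3)cnn2CC#N)c1` — 17%
compound 2 `COc1cc(C)cc(-c2nn(CC#N)cc2-c2ccnc(-c3ccc(N(C)C)cc3)c2)c1` — -15%
compound 3 `Cc1cc(O)cc(-c2nn(CC#N)cc2-c2ccnc(-c3ccc(N(C)C)cc3)c2)c1` — 11%

Within this set compound 1 gives the highest of the three numbers, that is, the weakest effect at the concentration tested. Compound 3 lies within the usual scatter of compound 1, so the two cannot be told apart. Compound 2 lies beyond the scatter, some distance lower. For the measured compounds named here, the only step that can be read between two measured compounds is a number 26 percentage points higher from compound 2 to compound 3 (beyond the scatter), hydrogen in place of methyl on an oxygen on an aromatic ring; it concerns a different part of the molecule from the change considered here.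

Compound 4 `COc1cc(C)cc(-c2c(-c3ccnc(-c4ccc(C(C)=O)cc4)c3)cnn2CC#N)c1` differs from compound 1 in one place: acetyl in place of dimethylamino on an aromatic carbon The exchanged group sits para to a large group. Going by the values given here, no measured step covers this exchange, and nothing in the three numbers shows how the ring bearing the dimethylamino responds to a change there. Among the compounds with values here, with no bearing step, the expectation for compound 4 is a step of no clear direction, most likely none beyond the scatter, with a wide range to allow for either way. The estimate for compound 4 is 15%, between -15% and 45%, corresponding to an expected a number 2 percentage points lower from compound 1 to compound 4 (within the scatter).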

Compound 4, a percentage reported as activity, at one concentration (the size of the read-out at that concentration, not a potency): 21%
Compound 4: middle estimate off by 6 percentage points, on the low side, and the stated range covers the measured number.
By their numbers in this assay, from the lowest: compound 2; then compounds 3, 1 and 4 (each within the scatter of the next).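

In this assay, acetyl in place of dimethylamino on the aromatic carbon gives a number 4 percentage points higher from compound 1 to compound 4 (within the scatter), so 4-(dimethylamino)phenyl and 4-acetylphenyl cannot be told apart at the concentration tested. For the compounds shown here, this is the first reading at this position, and it shows that replacing the nitrogen-bearing group with one carrying a carbonyl leaves the read-out within the scatter. No measurement available here bears on this result.

Still open, from the compounds shown here alone, is whether a group of a different kind at this place, such as a primary amine, a carboxylic acid or a longer alkyl chain, would also stay within the scatter of compound 1. Also open, going by these compounds, is whether the same exchange would read the same way on the core of compound 2, and a reading at a single concentration leaves any difference in potency between compound 1 and compound 4 unresolved.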